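A few compounds are considered here, and "the series" means these few. Any claim that something is new, unique, unknown or untested is made for them only; others in the source may bear on it.

Of the compounds shown here, three with a shared core have been tested in an ADME assay on NIH3T3 cells (Mus musculus) for cytotoxicity, read by MTT assay, with a stated time of 24 h; a lower number here means a stronger inhibitor, a higher number a weaker inhibitor. Compound 1 `Cc1nnc(SCC(=O)N/N=c2/scc(-c3ccccc3)n2-c2ccccc2)s1` gives 197 ug/mL, and compound 2 `COc1ccc(-c2cs/c(=N/NC(=O)CSc3nnc(C)s3)n2-c2ccccc2)cc1` gives 300 ug/mL, which is a 1.5-fold higher number from compound 1 to compound 2 (0.18 log units; within the scatter). Compound 3 `Cc1nnc(SCC(=O)N/N=c2/scc(-c3ccc(C#N)cc3)n2-c2ccccc2)s1` reads < 3.9 ug/mL, and this is a limit of the assay, not a number. Compound 1 therefore sits level with compound 2 and well apart from compound 3. Cyano in place of hydrogen gives an at least 50-fold lower number from compound 1 to compound 3 (1.70 log units; beyond the scatter), and cyano in place of methoxy gives an at least 76-fold lower number from compound 2 to compound 3 (1.88 log units; beyond the scatter).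

Compound 4 `Cn1cnnc1SCC(=O)N/N=c1/scc(-c2ccccc2)n1-c1ccccc1` has not been measured yet. It differs from compound 1 in another part of the molecule: 4-methyl-4H-1,2,4-triazol-3-yl in place of 5-methyl-1,3,4-thiadiazol-2-yl on a sulfur. Here 4-methyl-4H-1,2,4-triazol-3-yl takes the place of 5-methyl-1,3,4-thiadiazol-2-yl on a sulfur whose other neighbour is a saturated chain carbon.

All three measured steps swap a group on an aromatic carbon, so none of them tests this sulfur substituent directly. Among the compounds with values here, they show only that one swap can leave the reading unchanged, while another can produce an at least 50-fold lower number from compound 1 to compound 3 (1.70 log units; beyond the scatter). With no direct evidence for a shift, the expected result in this assay is a 1.0-fold higher number from compound 1 to compound 4 (0.01 log units; within the scatter), meaning no step beyond the scatter. For compound 4 the estimated value is 200 ug/mL, with an expected range of 50 ug/mL to 450 ug/mL.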

Compound 4, half-maximal inhibitory concentration: 217 ug/mL
Compound 4: middle estimate off by 1.1-fold (0.04 log units), on the low side, within the range that was stated.
By their numbers in this assay, from the lowest: compounds 1, 4 and 2 (each within the scatter of the next). At a limit, below all of these: compound 3.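

In this assay, within the data shown here, this is the first direct test of the sulfur substituent: 4-methyl-4H-1,2,4-triazol-3-yl in place of 5-methyl-1,3,4-thiadiazol-2-yl gives a 1.1-fold higher number from compound 1 to compound 4 (0.04 log units; within the scatter) and so no step beyond the scatter. The two groups have the same count of heavy atoms, hydrogen-bond donors and hydrogen-bond acceptors, but the entering group has one more nitrogen and no sulfur, so in this one pair that exchange, on a sulfur whose other neighbour is a saturated chain carbon, leaves the reading level, unlike the large step seen with the cyano group on an aromatic carbon. Nothing measured here shows why the reading stays level at this position.

Going by these compounds, compound 3 reads < 3.9 ug/mL and that is a limit of the assay, so it remains open whether the same exchange of rings would also leave the reading level on a compound carrying the cyano group. Also open, on these data alone, is whether a group of a different kind on this sulfur, such as a longer chain or a carboxylic acid, would keep the reading level or shift it beyond the scatter.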